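The source may report more compounds than this note shows. Statements on the series, on what has been measured and on what is new or still open speak of the compounds shown alone.

Measured compounds in an ADME assay on Raji cells (Homo sapiens) for cytotoxicity, with a stated time of 72 h; on this read-out lower numbers stand for an effect already at smaller amounts and higher numbers for an effect only at larger amounts of compound:

- compound 1 `Cc1cc(NC(=O)Nc2ccc(N)cc2)c2ccccc2n1` — in this assay compound 1 gives > 25000 nM, which is a limit of the assay and not a number.
- compound 2 `Cc1cc(NC(=O)Nc2cccc(C(F)(F)F)c2)c2ccccc2n1` — compound 2 gives 10000 nM.
- compound 3 `Cc1cc(NC(=O)Nc2cccnc2)c2ccccc2n1` — compound 3 gives > 25000 nM, again a limit of the assay.

Compound 1 thus stands at the upper end of what this assay can report; only a limit is known for it, and (the limit of > 25000 nM in this assay, at which 2 of the 3 values shown sit). Compound 4 `Cc1cc(NC(=O)Nc2ccc(C(C)(C)C)cc2)c2ccccc2n1` is not yet measured. Against compound 1 it carries tert-butyl in place of amino on an aromatic carbon.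

Within the data shown here, the one step between measured compounds that changes a single place is a step that the two limits leave unreadable from compound 1 to compound 3; with both ends at the limit its size cannot be read. Among the measured compounds shown here, no measured step therefore bears directly on the change to compound 4, and no direction can be taken from the data. For the measured compounds named here, compound 2 is the only compound of the three that gives a number in this assay, so a reading inside the assay range is at least possible for this core. Whether tert-butyl brings compound 4 inside that range is open.

Compound 4 is estimated at 12000 nM, with a range from 4000 nM to 30000 nM. Against compound 1 this estimate means an expected step of an at least 2.0-fold lower number from compound 1 to compound 4 (0.31 log units; beyond the scatter), with a substantial chance that only a limit is reported again.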

Compound 4, half-maximal effective concentration: > 25000 nM
Compound 4 ended at the assay's limit; the forecaster's own chance of this, stated with the estimate: 45%; at least 2.0-fold (0.31 log units) between middle value and limit.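

In this assay, compound 4 and compound 1 both end at a limit and not at a number, so the step between them cannot be read: the limit of > 25000 nM in this assay, at which 3 of the 4 values shown sit.

As far as these compounds go, how far compound 1, compound 3 and compound 4 lie past that limit, and so how they rank among themselves, remains open.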